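Swapping a styryl arm for furan on the oxindole exocyclic alkene

The source may hold more compounds than are shown below. What is called first, only, known or untested is meant among the compounds shown, and "the series" means these compounds.

The series shares a peracetylated sugar carried on a triazole-linked oxindole core. Compound 1 `CC(=O)OC[C@H]1O[C@@H](n2cc(Cn3cc(/C=C4/C(=O)Nc5ccccc54)c4ccccc43)nn2)[C@H](OC(C)=O)[C@@H](OC(C)=O)[C@@H]1OC(C)=O` bears the core through a different attachment, and in a functional assay on DU-145 cells (Homo sapiens) for cytotoxicity, read by sulforhodamine B assay, with a stated time of 48 h (a higher number here means a weaker inhibitor, a lower number a stronger inhibitor), compound 1 gives only a limit, > 200000 nM, not a number. Compound 2 `CC(=O)OC[C@H]1O[C@@H](n2cc(CN3C(=O)/C(=C\C=C\c4ccccc4)c4ccccc43)nn2)[C@H](OC(C)=O)[C@@H](OC(C)=O)[C@@H]1OC(C)=O` gives 19500 nM in this assay. Compound 3 `CC(=O)OC[C@H]1O[C@@H](n2cc(CN3C(=O)/C(=C/C=C/c4ccccc4)c4ccccc43)nn2)[C@H](OC(C)=O)[C@@H](OC(C)=O)[C@@H]1OC(C)=O` gives 17100 nM in this assay, the lowest of the two numbers shown, though the step of a 1.1-fold lower number from compound 2 to compound 3 (0.06 log units; within the scatter) stays within the scatter, so compounds 2 and 3 cannot be ranked; that pair differs only in configuration as drawn (the fact that compounds 2 and 3 differ only in the configuration as drawn).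

Compound 4 `CC(=O)OC[C@H]1O[C@@H](n2cc(CN3C(=O)/C(=C/c4ccco4)c4ccccc43)nn2)[C@H](OC(C)=O)[C@@H](OC(C)=O)[C@@H]1OC(C)=O` differs from compound 3 by furan-2-yl in place of 2-phenylethenyl on a double-bonded chain carbon bound to a double-bonded ring carbon. Among the measured compounds shown here, no measured step changes this part of the molecule, so the one counted step offers no guide to direction; the only comparable change, between compounds 2 and 3, produced no movement beyond the scatter. Compound 4 is therefore expected near compound 3, an estimated step of a 1.2-fold higher number from compound 3 to compound 4 (0.07 log units; within the scatter) that is more uncertain than large. For compound 4 the estimate in this assay is 20000 nM, between 5000 nM and 80000 nM.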

Compound 4, half-maximal inhibitory concentration: 10000 nM
The estimate for compound 4 lay 2.0-fold (0.30 log units) above the measured number; the measured number falls inside the stated range.
By their numbers in this assay, from the lowest: compounds 4, 3 and 2 (each within the scatter of the next). At a limit, above all of these: compound 1.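

Compound 4 replaces the group itself, on a double-bonded chain carbon bound to a double-bonded ring carbon, whereas the earlier pair differed only in configuration as drawn. In this assay, furan-2-yl in place of 2-phenylethenyl gives a 1.7-fold lower number from compound 3 to compound 4 (0.23 log units; within the scatter), so a shorter substituent with a five-membered aromatic ring and a hydrogen-bond acceptor leaves the number within the scatter of the one with the six-membered ring and the extra double bond. Nothing shown accounts for this step.

On these data alone, it remains open whether any group at this place can move the number beyond the scatter, such as an amine or a carboxylic acid, neither of which carries an aromatic ring like the two groups compared here. Also open, as far as these compounds go, is whether the drawn configuration of the double bond matters with furan-2-yl attached.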